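A few compounds are considered here, and "the series" means these few. Any claim that something is new, unique, unknown or untested is made for them only; others in the source may bear on it.

Measured so far in a functional assay on QGY7701 cells (Homo sapiens) for cytotoxicity, read by MTT assay, with a stated time of 24 h; a lower number here means a stronger inhibitor, a higher number a weaker inhibitor:
- compound 1 `C=CC1=C(C(=O)NCCCCC)C(c2ccc(OC)cc2)OC1`: compound 1 gives only the assay limit > 100000 nM.
- compound 2 `C=CC1=C(C(=O)Nc2ccc(C)cc2)C(c2ccc(F)cc2)OC1`: compound 2 gives 59200 nM.
- compound 3 `C=CC1=C(C(=O)Nc2ccc(OCC)cc2)C(c2ccc(F)cc2)OC1`: compound 3 gives 61600 nM.

Compound 2 holds the lowest of the two numbers shown, with compound 3 within the scatter of it; the step of a 1.0-fold higher number from compound 2 to compound 3 (0.02 log units; within the scatter) shows no change beyond that scatter. Compound 1 sits at the limit of > 100000 nM in this assay, at which 1 of the 3 values shown sits, and differs from compound 2 in two places, so its value cannot be tied to either change alone.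

Compound 4 `C=CC1=C(C(=O)NCc2ccccc2F)C(c2ccc(F)cc2)OC1` is unmeasured. It differs from compound 2 by 2-fluorobenzyl in place of 4-methylphenyl on an amide-type nitrogen. Going by the values given here, no measured step exchanges the group on the amide nitrogen, so the single measured step, ethoxy for methyl on an aromatic carbon, bears on it only by showing that the shared core tolerates small changes without movement beyond scatter. Compound 4 is therefore expected to lie near compound 2, with a modest step of a 1.3-fold higher number from compound 2 to compound 4 (0.10 log units; within the scatter) towards a weaker number, given that compound 1, with a different group on the amide nitrogen, reached the limit. The estimate for compound 4 is 75000 nM, between 35000 nM and 160000 nM.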

Compound 4, half-maximal inhibitory concentration: 51400 nM
Compound 4: middle estimate off by 1.5-fold (0.16 log units), on the high side; measured number inside the range.
By their numbers in this assay, from the lowest: compounds 4, 2 and 3 (each within the scatter of the next). At a limit, above all of these: compound 1.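

At the amide-type nitrogen, 2-fluorobenzyl in place of 4-methylphenyl gives a 1.2-fold lower number from compound 2 to compound 4 (0.06 log units; within the scatter) in this assay. The group on this nitrogen, and not only the substituent on its aromatic ring, can therefore be exchanged here without movement beyond the scatter. No measured property bears on this step.

Compound 1 gives > 100000 nM, which is a limit of the assay, and it differs from compound 2 in two places. Open, on these data alone, is what a longer alkyl chain or an amine on the amide-type nitrogen would do with the rest of compound 2 kept.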